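The compounds below may be only part of what the source reports. "The series", "measured", "known", "first", "only" and "open" are said of these compounds alone.

Compound 1 `O=C(O)CCc1ccc(NCc2ccc(C(F)(F)F)cc2)cc1` and compound 2 `O=C(O)CCc1ccc(NCc2ccccc2Cl)cc1` share one core and differ only in the group carried on the benzyl ring. In a functional assay for agonist activity at Free fatty acid receptor 1 (Homo sapiens) (on this read-out higher numbers stand for an effect only at larger amounts of compound and lower numbers for an effect already at smaller amounts), compound 1 gives 2000 nM, and in this assay compound 2 gives 3980 nM. Compound 1 thus holds the lower of the two numbers, yet its separation from compound 2 lies within the scatter of repeated measurements, so the two cannot be told apart with any confidence. Within the data shown here, no step between compounds that differ in a single place has been measured, so nothing is known yet about how a change on the benzyl ring moves the read-out.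

Compound 3 `O=C(O)CCc1ccc(NCc2ccc(O)cc2)cc1` has not been measured. It differs from compound 1 in one place: hydroxy in place of trifluoromethyl on an aromatic carbon. Among the measured compounds shown here, with only two measured compounds, neither of which shows how this position answers to a change, the expected step of a 2.5-fold higher number from compound 1 to compound 3 (0.40 log units; beyond the scatter) is modest and of uncertain direction, and a result within the scatter of compound 1 would not surprise. The estimate for compound 3 is 5000 nM, with a range from 1500 nM to 20000 nM.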

Compound 3, half-maximal effective concentration: < 31700 nM
Compound 3 gave a limit, no number; the forecaster's own chance of this, stated with the estimate: 15%; the middle value lies beyond the limit too.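

Compound 3 gave only a limit and no number, so the step from compound 1 to compound 3 cannot be read: the limit of < 31700 nM in this assay, at which 1 of the 3 values shown sits. The compounds shown leave open how far hydroxy in place of trifluoromethyl on an aromatic carbon moves the read-out, and in which direction, and how any other change on the benzyl ring would move it.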